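Amide-to-urea switch on the chloro-trifluoromethylphenyl arm

The source may report more compounds than this note shows. Statements on the series, on what has been measured and on what is new or still open speak of the compounds shown alone.

Measured compounds in a functional assay on OVCAR-3 cells (Homo sapiens) for inhibition, read by sulforhodamine B assay, with a stated time of 48 h; a lower number here means a stronger inhibitor of growth, a higher number a weaker inhibitor of growth:
compound 1, `COc1cc(-c2nn(-c3cccc(NC(=O)c4cccc(C(F)(F)F)c4)c3)cc2-c2ccncc2)ccc1Cl`, 1200 nM
compound 2, `COc1cc(-c2nn(-c3cccc(NC(=O)Nc4ccc(Cl)c(Cl)c4)c3)cc2-c2ccncc2)ccc1Cl`, 697 nM
compound 3, `COc1cc(-c2nn(-c3cccc(NC(=O)c4ccc(Cl)c(C(F)(F)F)c4)c3)cc2-c2ccncc2)ccc1Cl`, 2420 nM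

Compound 3 gives the highest number of the three in this assay . Its nearest neighbour is compound 1, a 2.0-fold higher number from compound 1 to compound 3 (0.30 log units; within the scatter); its furthest is compound 2, a 3.5-fold higher number from compound 2 to compound 3 (0.54 log units; beyond the scatter).

Compound 4, `COc1cc(-c2nn(-c3cccc(NC(=O)Nc4ccc(Cl)c(C(F)(F)F)c4)c3)cc2-c2ccncc2)ccc1Cl`, is not yet measured. It differs from compound 3 in one place: (4-chloro-3-(trifluoromethyl)phenyl)amino in place of 4-chloro-3-(trifluoromethyl)phenyl on a carbonyl carbon.

The step that bears most directly on this change is a 1.7-fold lower number from compound 1 to compound 2 (0.24 log units; within the scatter), in which a carbonyl-linked aryl becomes an arylamino while the ring substitution also shifts. The step of a 3.5-fold higher number from compound 2 to compound 3 (0.54 log units; beyond the scatter) runs the same way but again mixes the linker change with a change in ring substitution, so neither isolates the amide-to-urea switch on its own. Among the compounds with values here, compound 4 and compound 2 share the urea linker but carry different ring substitution, and no single step connects them.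

Taken together, a modest move towards a lower number is expected in this assay for compound 4, a 1.9-fold lower number from compound 3 to compound 4 (0.27 log units; within the scatter). The estimate for compound 4 is 1300 nM, with a range from 500 nM to 3500 nM.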

Compound 4, concentration for 50% growth inhibition: 889 nM
Compound 4: the middle estimate sits 1.5-fold (0.17 log units) above what was measured; low and high end bracket the measured number.
By their numbers in this assay, from the lowest: compounds 2, 4, 1 and 3 (each within the scatter of the next, the first and the last beyond it).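

In this assay, within the data shown here, the amide-to-urea switch can now be read on its own, with the ring substitution held at 4-chloro-3-(trifluoromethyl)phenyl: a 2.7-fold lower number from compound 3 to compound 4 (0.43 log units; beyond the scatter), a modest step beyond the scatter, whereas the earlier steps mixed the linker with a change of ring substitution. Among the compounds with a urea linker, trifluoromethyl in place of chloro gives a 1.3-fold higher number from compound 2 to compound 4 (0.11 log units; within the scatter), and the comparison with the 3-(trifluoromethyl)phenyl amide gives a 1.3-fold lower number from compound 1 to compound 4 (0.13 log units; within the scatter), so compound 4 cannot be separated from compound 2 or compound 1 in this series, as both steps lie within the scatter. No measurement here bears on why the urea and the amide differ on this arm.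

From the compounds shown here alone, the linker effect rests on a single matched pair, so it remains open whether the same switch shifts the number on the 3-(trifluoromethyl)phenyl or 3,4-dichlorophenyl arms. Also open, going by these compounds, is how a thiourea or a sulfonamide would read in place of the urea on the 4-chloro-3-(trifluoromethyl)phenyl arm.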